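A few compounds are considered here, and "the series" means these few. Any claim that something is new, unique, unknown or untested is made for them only; others in the source may bear on it.

Measured in an ADME assay on microsomes from liver (Homo sapiens) for metabolic stability, tested at 2.5 uM; a higher number here means faster removal of the compound, a lower number slower removal:
compound 1 `O=S(=O)(c1cc(F)cc(F)c1)c1cnc2c(F)cccc2c1-c1ccccc1F` gives 0.09 mL/min;
compound 2 `O=S(=O)(c1ccc(F)c(Cl)c1)c1cnc2c(F)cccc2c1-c1cccc(F)c1` gives 1.23 mL/min;
compound 3 `O=S(=O)(c1cccc(F)c1)c1cnc2c(F)cccc2c1-c1cccc(F)c1` gives 1.14 mL/min.

Compound 3 sits second highest of the three numbers in this assay. Its nearest neighbour is compound 2, whose value lies within the scatter of that of compound 3; the step of a 1.1-fold lower number from compound 2 to compound 3 (0.03 log units; within the scatter) is within the scatter. Compound 1 is the furthest, with a number far below that of compound 3, beyond the scatter, but compound 1 differs from compound 3 in two places, so its values alone cannot be attributed to one change.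

Compound 4 `O=S(=O)(c1cc(F)cc(F)c1)c1cnc2c(F)cccc2c1-c1cccc(F)c1` is not yet measured. Against compound 3 the change is fluoro in place of hydrogen on an aromatic carbon. Going by the values given here, the only step among the measured compounds that varies the same phenyl on the sulfonyl sulfur is that from compound 2 to compound 3, which was within the scatter. Compound 1 shares the 3,5-difluorophenyl of compound 4 on the sulfonyl sulfur and gives the lowest number, which hints at a lower value, but the second difference in compound 1 leaves this uncertain. The expected step of a 1.9-fold lower number from compound 3 to compound 4 (0.28 log units; within the scatter) is therefore a modest lowering, and compound 4 is estimated at 0.6 mL/min with a range from 0.2 mL/min to 1.5 mL/min.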

Compound 4, intrinsic clearance in a liver preparation (reported as CLH), per the amount of preparation that the assay uses: 1.18 mL/min
The estimate for compound 4 lay 2.0-fold (0.29 log units) below the measured number; the measured number falls inside the stated range.
By their numbers in this assay, from the lowest: compound 1; then compounds 3, 4 and 2 (each within the scatter of the next).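

In this assay, fluoro in place of hydrogen on the phenyl on the sulfonyl sulfur gives no readable change, with a 1.0-fold higher number from compound 3 to compound 4 (0.01 log units; within the scatter), and 3,5-difluorophenyl in place of 3-chloro-4-fluorophenyl gives none either, with a 1.0-fold lower number from compound 2 to compound 4 (0.02 log units; within the scatter), so the three sulfonyl phenyls of compounds 2, 3 and 4 read alike on this core. Going by these compounds alone, the large difference lies on the other phenyl: with the 3,5-difluorophenyl held constant, 3-fluorophenyl in place of 2-fluorophenyl gives a 13-fold higher number from compound 1 to compound 4 (1.12 log units; beyond the scatter), the first single-place comparison that reaches compound 1. No measured evidence bears on the origin of these numbers.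

From the compounds shown here alone, whether the low number of compound 1 persists with the other sulfonyl phenyls remains open. Also open, going by these compounds, is how an amine or a carboxylic acid on the sulfonyl phenyl would read in this assay.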